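Replacing 3-(aminomethyl)phenyl with pyridin-2-yl on the amide

A few compounds are considered here, and "the series" means these few. Any claim that something is new, unique, unknown or untested is made for them only; others in the source may bear on it.

Compound 3 `CC(C)(C)c1cc(C(=O)Nc2cccc(CN)c2)n(Cc2ccccc2)n1` reads > 100 ug/mL in a physicochemical assay for solubility, read by nephelometry, measured as kinetic solubility, at pH 2.0 (a higher number here means a more soluble compound, a lower number a less soluble compound), as its result, which is a limit of the assay and not a number. Compound 1 `NCc1csc(NC(=O)c2ccccn2)n1` reads > 100 ug/mL as its result, again a limit. Compound 2 `NCc1csc(NC(=O)c2ccon2)n1` gives 50 ug/mL as a true number. Compound 3 therefore stands at the limit, with its actual solubility unseen. In compound 4 `CC(C)(C)c1cc(C(=O)Nc2ccccn2)n(Cc2ccccc2)n1` pyridin-2-yl takes the place of 3-(aminomethyl)phenyl on an amide-type nitrogen (pyridin-2-yl in place of 3-(aminomethyl)phenyl on an amide-type nitrogen). Going by the values given here, no measured step shows what this swap does, but a fall beyond the usual scatter is expected. The expected change is an at least 2.5-fold lower number from compound 3 to compound 4 (0.39 log units; beyond the scatter) in this assay terms. Compound 4 is expected at 40 ug/mL within an estimated range of 10 ug/mL to 100 ug/mL in this assay readings.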

Compound 4, solubility: 25 ug/mL
For compound 4 the middle estimate is 1.6-fold (0.20 log units) above the measured one, and the stated range covers the measured number.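

Going by these compounds alone, measured in this assay the swap of 3-(aminomethyl)phenyl for pyridin-2-yl on this amide-type nitrogen gives an at least 4.0-fold lower number from compound 3 to compound 4 (0.60 log units; beyond the scatter) and so shows for the first time, in a single step, that changing this group moves the reading. The full size of the drop stays unseen, since the result of compound 3 is a limit and not a number: the limit of > 100 ug/mL in this assay, at which 2 of the 4 values shown sit.

From the compounds shown here alone, the swap changes the ring and removes the aminomethyl group together, so the share of each remains open. A plain phenyl on the same nitrogen would begin to separate them.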